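Chlorine walk on the benzyl group of the naphthamide series

This account rests on a few compounds, and the source may have more. Where it says the series, first, only, none or still open, it means among the compounds named here.

Of the compounds shown here, two of this set have been measured in an assay on isolated protein for displacement of a labelled ligand from D(4) dopamine receptor (Homo sapiens); a lower number here means a stronger inhibitor, a higher number a weaker inhibitor. Compound 1, `O=C(NC1CCN(Cc2ccccc2Cl)CC1)c1cccc2ccccc12`, gives 329 nM. Compound 2, `O=C(NC1CCN(Cc2cccc(Cl)c2)CC1)c1cccc2ccccc12`, gives 116 nM. Within the data shown here, the one counted step, a 2.8-fold lower number from compound 1 to compound 2 (0.45 log units; beyond the scatter), places compound 2 at the lowest number of the two, with compound 1 the nearest neighbour and the gap between them beyond the scatter.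

Compound 3, `O=C(NC1CCN(Cc2ccc(Cl)cc2)CC1)c1cccc2ccccc12`, is not yet measured. Its difference from compound 2 is 4-chlorophenyl in place of 3-chlorophenyl on a saturated chain carbon bound to an amine nitrogen in a ring; the two share every atom, joined differently. Among the measured compounds shown here, no measured step covers this exact change. For the measured compounds named here, the only step available, from compound 1 to compound 2, moved the same chlorine on the same phenyl ring and gave a modest gain; it bears on the present step only in showing that the chlorine's placement on this ring matters to this assay at a modest level. A further shift of the chlorine is therefore expected to give at most a modest step in this assay, direction uncertain, more likely toward a lower number or none beyond the scatter.

For compound 3 the expected result in this assay is 80 nM, within 30 nM to 250 nM, corresponding to an estimated step of a 1.5-fold lower number from compound 2 to compound 3 (0.16 log units; within the scatter).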

Compound 3, inhibition constant: 43 nM
Estimate against measurement, compound 3: 1.9-fold (0.27 log units) above, and the stated range covers the measured number.
By their numbers in this assay, from the lowest: compound 3; then compound 2; then compound 1.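

Notes on the chlorine walk: in this assay, the move to 4-chlorophenyl on a saturated chain carbon bound to an amine nitrogen in a ring continues in the direction of the earlier step (a 2.8-fold lower number from compound 1 to compound 2 (0.45 log units; beyond the scatter)) with a second step beyond the scatter (a 2.7-fold lower number from compound 2 to compound 3 (0.43 log units; beyond the scatter)). Across the whole walk the change is larger than either single step (a 7.7-fold lower number from compound 1 to compound 3 (0.88 log units; beyond the scatter)), although the leaving and entering groups have the same atoms and the same counts, so the placement of the chlorine alone separates these three compounds, and compound 3 is the strongest of them in this series. No evidence at hand accounts for this order of the three numbers.

Still open, going by these compounds, is whether this order belongs to chlorine or would also appear with another group on the same phenyl ring, such as fluorine, methyl, methoxy or trifluoromethyl, and how the plain unsubstituted benzyl group compares with the three chlorobenzyl groups. Also open, on these data alone, is whether the 4-chlorophenyl group would keep its lead on a longer chain in place of the present saturated chain carbon.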